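Aryl urea series: aminopyrimidine anilines, cell growth inhibition

This account rests on a few compounds, and the source may have more. Where it says the series, first, only, none or still open, it means among the compounds named here.

Measured compounds and their values in a functional assay on PC-9 cells (Homo sapiens) for inhibition, read by MTT assay, with a stated time of 48 h, tested at 10 uM; on this read-out higher numbers stand for more inhibition at the one concentration tested (going by the name of the read-out) and lower numbers for less inhibition:
- compound 1 `COc1cc(NC(=O)Nc2cc(Nc3ccc(OC)c(C)c3)ncn2)cc(OC)c1` gives 62%
- compound 2 `COc1ccc(C(F)(F)F)cc1Nc1cc(NC(=O)Nc2c(Cl)cccc2Cl)ncn1` gives 89%
- compound 3 `COc1cc(Nc2cc(NC(=O)Nc3c(Cl)cccc3Cl)ncn2)cc(C(F)(F)F)c1` gives 88.5%

Compound 1 stands lowest of the three numbers in this assay. The nearest is compound 3, whose number lies higher by a margin beyond the usual scatter; compound 2 lies higher still, also beyond the scatter. Among the measured compounds shown here, compounds 2 and 3 differ from compound 1 in more than one place, so no single step between measured compounds can be drawn from them, and the values are taken only as they stand.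

Compound 4 `COc1cc(NC(=O)Nc2cc(Nc3ccc(C(C)(C)C)cc3)ncn2)cc(OC)c1` is not yet measured. It departs from compound 1 by one change: 4-(tert-butyl)phenyl in place of 4-methoxy-3-methylphenyl on a nitrogen on an aromatic ring. The aniline ring on the shared core keeps its attachment point; the substituent pattern on that ring changes, as counted above.

Nothing in the measured set isolates this aniline position, so no step size can be computed for it. The expectation for this assay is a step of no more than modest size in either direction, most likely within the scatter, expressed as a number 3 percentage points higher from compound 1 to compound 4 (within the scatter). Compound 4 is accordingly expected to give about 65%, with a range from 45% to 85%.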

Compound 4, a percentage reported as inhibition, at one concentration (the size of the read-out at that concentration, not a potency): 74.1%
For compound 4 the middle estimate is 9.1 percentage points below the measured one; low and high end bracket the measured number.
By their numbers in this assay, from the lowest: compound 1; then compound 4; then compounds 3 and 2 (each within the scatter of the next).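

In this assay, among the compounds shown here, 4-(tert-butyl)phenyl in place of 4-methoxy-3-methylphenyl on a nitrogen on an aromatic ring gives a number 12.1 percentage points higher from compound 1 to compound 4 (beyond the scatter), the first step that isolates this place on the shared core. The earlier compounds shown here differed in more than one place and could not show that this position alone moves the read-out; the step is modest but beyond the scatter. It also shows that at this place an all-carbon group with no hydrogen-bond acceptor can stand in for the oxygen-bearing group without a loss of inhibition at the one concentration tested, and nothing at hand gives a reason for the size of the step.

For the compounds shown here, the single pair cannot separate the part played by the departing methoxy and methyl groups from that of the entering tert-butyl group, and it cannot say whether the step would carry over to the other aniline and urea groups of compound 2 and compound 3. It also leaves open how this position would respond to a morpholine or a carboxylic acid on the same ring.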